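From compound 3 to compound 4: adding nitro

The source may hold more compounds than are shown below. What is called first, only, known or untested is meant among the compounds shown, and "the series" means these compounds.

Compound 1 (`CC(C)(C)NCc1c(C(=O)O)nn(-c2ccccc2)c1-c1ccc(Cl)cc1`), compound 2 (`CC(C)(C)NCc1c(C(=O)O)nn(-c2ccccc2)c1-c1ccc(Br)cc1`) and compound 3 (`CC(C)(C)NCc1c(C(=O)O)nn(-c2ccccc2)c1-c1ccccc1`) share one core and differ in a single aromatic substituent. In a functional assay on MCF7 cells (Homo sapiens) for inhibition, read by sulforhodamine B assay, with a stated time of 48 h (a lower number here means a stronger inhibitor of growth, a higher number a weaker inhibitor of growth), compound 2 gives 293000 nM. Compound 1 gives > 652000 nM, which is a limit. Compound 3 gives > 716000 nM, also a limit and not a number, so the starting point of this step is unmeasured.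

Compound 4 (`CC(C)(C)NCc1c(C(=O)O)nn(-c2ccccc2)c1-c1ccc([N+](=O)[O-])cc1`) carries nitro in place of hydrogen on an aromatic carbon, para to a large group: nitro in place of hydrogen on an aromatic carbon.

The bearing steps are an at least 2.2-fold lower number from compound 1 to compound 2 (0.34 log units; beyond the scatter) and an at least 2.4-fold higher number from compound 2 to compound 3 (0.38 log units; beyond the scatter), both beyond the scatter, while a step that the two limits leave unreadable from compound 1 to compound 3 cannot be read. Bromo in compound 2 thus gives a readable separation from compound 3, whereas chloro in compound 1 does not, and neither substituent is nitro. The expected change in this assay is modest and towards a lower number, and another limit remains quite possible. The expected step is an at least 1.8-fold lower number from compound 3 to compound 4 (0.27 log units; that floor lies within the scatter). For compound 4 the estimate is 380000 nM, with an expected range of 170000 nM to 650000 nM.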

Compound 4, concentration for 50% growth inhibition: > 634000 nM
Compound 4 was reported as a limit; the forecaster's own chance of this, stated with the estimate: 45%; at least 1.6-fold (0.22 log units) between middle value and limit.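

In this assay compound 4 gives > 634000 nM, which is a limit and not a number. Nitro on this aromatic carbon, para to a large group, thus yields no measured growth inhibition, and among the four substituents shown only bromo in compound 2 gives a number. Among these compounds, the one readable step is an at least 2.1-fold higher number from compound 2 to compound 4 (0.33 log units; beyond the scatter), while the steps to compound 4 from compound 1 and from compound 3 cannot be read, so nitro cannot be ranked against chloro or hydrogen.

Going by these compounds, whether an amine, a methoxy group or iodo on this same aromatic carbon would give a number in this assay stays open. On these data alone, it also stays open whether the separation of compound 2 from compound 4 would persist with a change elsewhere on the shared core.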